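A few compounds are considered here, and "the series" means these few. Any claim that something is new, unique, unknown or untested is made for them only; others in the source may bear on it.

Measured compounds:
Compound 1, `CC(=O)N1CCN(CC(=O)N2CCN(c3cc4c(cc3F)c(=O)c(C(=O)O)cn4C3CC3)CC2)CC1`: 16.2%
Compound 2, `O=C(O)c1cn(C2CC2)c2cc(N3CCN(C(=O)CN4CCN(Cc5ccccc5)CC4)CC3)c(F)cc2c1=O`: 15.5%

In an ADME assay on RAW264.7 cells (Mus musculus) for cytotoxicity, read by MTT assay, with a stated time of 72 h, tested at 50 uM (a lower number here means less inhibition, a higher number more inhibition at the concentration tested (going by the name of the read-out)), compound 1 gives 16.2% and compound 2 gives 15.5%. For the measured compounds named here, the only measured step, a number 0.7 percentage points lower from compound 1 to compound 2 (within the scatter), is within the scatter, so compound 2 sits alongside compound 1 rather than apart from it; the two readings cannot be told apart.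

Compound 3, `O=C(O)c1cn(C2CC2)c2cc(N3CCN(C(=O)CN4CCN(c5ccccc5Cl)CC4)CC3)c(F)cc2c1=O`, is the unmeasured member. Its change from compound 2 is 2-chlorophenyl in place of benzyl on an amine nitrogen in a ring. Going by the values given here, the one step that bears on it is the earlier exchange at the same ring nitrogen, a number 0.7 percentage points lower from compound 1 to compound 2 (within the scatter), which moved the reading by a negligible amount. Among the compounds with values here, with only that step as a guide, the exchange of benzyl for 2-chlorophenyl at that position is expected to shift the reading little: the step of a number 0.5 percentage points higher from compound 2 to compound 3 (within the scatter) is estimated to stay within the scatter. Compound 3 is therefore expected to give 16%, with a range from 5% to 28%.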

Compound 3, a percentage reported as inhibition, at one concentration (the size of the read-out at that concentration, not a potency): 14.9%
The estimate for compound 3 lay 1.1 percentage points above the measured number; measured number inside the range.
By their numbers in this assay, from the lowest: compounds 3, 2 and 1 (each within the scatter of the next).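

In this assay, 2-chlorophenyl in place of benzyl on the amine nitrogen in the ring gives a number 0.6 percentage points lower from compound 2 to compound 3 (within the scatter), and 2-chlorophenyl in place of acetyl gives a number 1.3 percentage points lower from compound 1 to compound 3 (within the scatter). The earlier pair held only acetyl and benzyl at this nitrogen, whereas the three compounds now show that a chlorine-bearing aromatic group can also stand there without a reading that can be told apart from the other two. No other measurement bears on this result, so it offers no account of why the readings stay together.

On these data alone, whether a plain phenyl, a carboxylic acid or a longer alkyl chain on this nitrogen would also stay within the scatter remains open. So does whether these three compounds would stay together at other concentrations.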